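The compounds below may be only part of what the source reports. "The series", "measured", "known", "first", "only" and "open" are said of these compounds alone.

Measured compounds:
- Compound 1, `COc1cc(Cn2cc(COc3cccc(/C=C4\C(=O)Nc5ccccc54)c3)nn2)cc(OC)c1`: "not determined" (no result reported)
- Compound 2, `O=C1Nc2cc(Cl)ccc2/C1=C\c1cccc(OCc2cn(Cc3ccccc3)nn2)c1`: 20100 nM
- Compound 3, `O=C1Nc2ccc([N+](=O)[O-])cc2/C1=C\c1cccc(OCc2cn(Cc3ccccc3)nn2)c1`: "not determined" (no result reported)

Among the compounds with values here, in a functional assay on DU-145 cells (Homo sapiens) for inhibition, read by MTT assay, with a stated time of 48 h (a higher number here means a weaker inhibitor, a lower number a stronger inhibitor), compound 2 gives 20100 nM, the only number in the set. Compound 3 has no number in this assay, and compound 1 likewise stands without one, so compound 3 cannot be placed against any measured neighbour. Compound 4, `O=C1Nc2ccc(C(=O)c3ccccc3)cc2/C1=C\c1cccc(OCc2cn(Cc3ccccc3)nn2)c1`, differs from compound 3 by benzoyl in place of nitro on an aromatic carbon. Within the data shown here, no measured pair shows the effect of this change, so no direction or size can be read from the data; a difference within the usual scatter is as plausible as a real shift. Compound 4 is therefore expected to land near the weak activity of compound 2, at an estimated 20000 nM with a range from 5000 nM to 80000 nM.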

Compound 4, half-maximal inhibitory concentration: > 50000 nM
Compound 4 was reported as a limit (the forecaster's own chance of this, stated with the estimate: 25%); middle value at least 2.5-fold (0.39 log units) away from the limit.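

Compound 4 gives > 50000 nM, a limit and not a number. Within the data shown here, with no number for compound 3, no step between compound 3 and compound 4 can be read. On these data alone, what benzoyl in place of nitro does to activity stays open.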